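Methylsulfonyl and Benzyl in Place of Phenylcarbamoyl

This account rests on a few compounds, and the source may have more. Where it says the series, first, only, none or still open, it means among the compounds named here.

Going by the values given here, compound 2 `CCCCc1ccc(CNC(=O)Nc2ccccc2)c(=O)n1Cc1ccc(-c2ccccc2-c2nn[nH]n2)cc1` gives 0% in a functional assay on the whole organism (artery) for inhibition, with Rattus norvegicus as the target, at a dose of 3 mg/kg by the intraduodenal route (on this read-out higher numbers stand for more inhibition at the one dose given (going by the name of the read-out) and lower numbers for less inhibition), the lowest of the two numbers known. Compound 1 `CCCCc1ccc(CN)c(=O)n1Cc1ccc(-c2ccccc2-c2nn[nH]n2)cc1` gives 2.8% in this assay, a number within the scatter of compound 2. Among the compounds with values here, the one measured step, a number 2.8 percentage points lower from compound 1 to compound 2 (within the scatter), alters the same amine nitrogen and so bears on the new compound. Compound 3 `CCCCc1ccc(CN(Cc2ccccc2)S(C)(=O)=O)c(=O)n1Cc1ccc(-c2ccccc2-c2nn[nH]n2)cc1` differs from compound 2 by benzyl(methylsulfonyl)amino in place of (phenylcarbamoyl)amino on a saturated chain carbon bound to an aromatic carbon. Within the data shown here, with only that small step as a guide, compound 3 is expected to show a number 5 percentage points higher from compound 2 to compound 3 (within the scatter), no step beyond the scatter. The inhibition of compound 3 is estimated at 5%, with a range from 0% to 25%.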

Compound 3, a percentage reported as inhibition, in the whole organism at one dose (the size of the read-out at that dose, not a potency): 41.2%
The estimate for compound 3 lay 36.2 percentage points below the measured number, and the stated range ends below it.
By their numbers in this assay, from the lowest: compounds 2 and 1 (each within the scatter of the next); then compound 3.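

In this assay, the amine nitrogen on the saturated chain carbon bound to an aromatic carbon now shows a large response to what it carries: a number 41.2 percentage points higher from compound 2 to compound 3 (beyond the scatter) and a number 38.4 percentage points higher from compound 1 to compound 3 (beyond the scatter) in the same series. Going by these compounds alone, the earlier step at this nitrogen stayed within the scatter, so benzyl(methylsulfonyl)amino is the first group here to set one compound apart. Nothing measured here accounts for the rise.

Going by these compounds, compound 3 brings benzyl and methylsulfonyl together, and whether either alone gives the gain stays open. A methylsulfonylamino group without the benzyl, or a benzylamino group without the methylsulfonyl, would separate the two.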